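Replacing the Butyl Chain of Compound 2

The source may hold more compounds than are shown below. What is called first, only, known or untested is meant among the compounds shown, and "the series" means these compounds.

In a physicochemical assay for solubility, read by nephelometry (on this read-out higher numbers stand for higher solubility and lower numbers for lower solubility), compound 1 `CCCCSc1nc(N)c2ncn(Cc3c(F)cccc3F)c2n1` gives 50000 nM. Compound 2 `CCCCOc1nc(N)c2ncn(Cc3c(F)ccc(C)c3F)c2n1` gives 50000 nM, which leaves it level with compound 1. Compound 3 `CCC(Oc1nc(N)c2ncn(Cc3c(F)ccc(C)c3F)c2n1)C(F)(F)C(F)(F)F` keeps the rest of compound 2 but carries 1-(1,1,2,2,2-pentafluoroethyl)propyl in place of butyl on an oxygen on an aromatic ring. Among the compounds with values here, no measured pair shows what a change of this kind does, so the expectation is loose. A moderate fall is expected, of the size a 2.0-fold lower number from compound 2 to compound 3 (0.30 log units; within the scatter), and it may stay close to the scatter. In this assay, compound 3 is estimated at 25000 nM, with a range from 6000 nM to 50000 nM.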

Compound 3, solubility: 25000 nM
Estimate against measurement, compound 3: no gap at the digits printed; low and high end bracket the measured number.
By their numbers in this assay, from the lowest: compounds 3, 1 and 2 (each within the scatter of the next).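

In this assay, 1-(1,1,2,2,2-pentafluoroethyl)propyl in place of butyl on an oxygen on an aromatic ring gives a 2.0-fold lower number from compound 2 to compound 3 (0.30 log units; within the scatter). At this position, then, a group of 10 heavy atoms, 5 of them fluorine, in place of one of 4 carbon atoms is not separated from butyl by this read-out. Nothing available offers an explanation for this result. The compounds shown leave open how a plain longer chain, an amine or a carboxylic acid on this oxygen would read, and they do not separate the contribution of the branched propyl part from that of the pentafluoroethyl part.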